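Putting a Carbon Ring on a Sulfonamide Nitrogen

The source may hold more compounds than are shown below. What is called first, only, known or untested is meant among the compounds shown, and "the series" means these compounds.

compound 1 `Cc1cc(COc2ccc(S(=O)(=O)NC(C)(C)CC(=O)NO)cc2)c2ccccc2n1` gives 1600000 nM
compound 2 `Cc1cc(COc2ccc(S(=O)(=O)NC3(CC(=O)NO)CN(C(=O)C(C)(C)N(C)C)C3)cc2)c2ccccc2n1` gives 11000000 nM

Both numbers come from a physicochemical assay for solubility, with a stated time of 24 h, tested at 30 mg/mL (on this read-out lower numbers stand for lower solubility and higher numbers for higher solubility), and compound 1 holds the lower of the two. Compound 2 stands above it by more than the usual scatter of repeated measurements. These two compounds differ in more than one place, so their gap cannot be tied to any single structural change.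

Compound 3 `Cc1cc(COc2ccc(S(=O)(=O)NC3(C(=O)NO)CCCC3)cc2)c2ccccc2n1` has not been measured yet. It departs from compound 1 in one place, on a sulfonamide nitrogen: a group of 9 heavy atoms (6 carbon, 1 nitrogen, 2 oxygen; one five-membered non-aromatic ring of carbon only) in place of a group of 8 heavy atoms (5 carbon, 1 nitrogen, 2 oxygen; no ring), on a sulfonamide nitrogen describes the swap. A group of 9 heavy atoms with one five-membered non-aromatic ring of carbon only replaces a group of 8 heavy atoms with no ring, and neither group has a net charge.

Among the compounds with values here, no measured pair isolates this kind of swap, so any forecast is loose and starts from compound 1 at 1600000 nM as the closest measured relative. In this assay the expected change is a 1.6-fold lower number from compound 1 to compound 3 (0.20 log units; within the scatter) which would be a small downward step within the usual scatter. The estimate for compound 3 is 1000000 nM with an expected range of 300000 nM to 3200000 nM for most repeat measurements.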

Compound 3, solubility: 200000 nM
For compound 3 the middle estimate is 5.0-fold (0.70 log units) above the measured one; measured number outside the range, below it.
By their numbers in this assay, from the lowest: compound 3; then compound 1; then compound 2.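

Within the data shown here, this position on a sulfonamide nitrogen is not silent in this assay: replacing a group of 8 heavy atoms with no ring by a group of 9 heavy atoms with one five-membered non-aromatic ring of carbon only comes with an 8.0-fold lower number from compound 1 to compound 3 (0.90 log units; beyond the scatter) and gives the first step here that can be tied to a single place in the structure. The change is also narrow on paper, since both groups have the same counts of hydrogen-bond donors, hydrogen-bond acceptors and double bonds outside aromatic rings, and neither has a net charge, so these counts do not separate the two groups although the numbers differ by more than the usual scatter. No measurement shown here accounts for the step.

Among these compounds, with only this one pair, the ring and the added carbon cannot be told apart as the source of the step. As far as these compounds go, it also remains open where a four-membered or six-membered ring of carbon only, or a ring holding an amine, would fall in this assay relative to compound 1 and compound 3, and whether the same swap would give a similar step on a different core.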